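The compounds below may be only part of what the source reports. "The series", "measured", "known", "first", "only" and "open" are said of these compounds alone.

The measured compounds:
compound 1, `COc1cccc(N2CCN(C(=O)C(C)N3C(=O)CCC3=O)CC2)c1`, 75%
compound 2, `CC(C(=O)N1CCN(c2ccccc2)CC1)N1C(=O)CCC1=O`, 100%
compound 3, `CCC(C(=O)N1CCN(c2cccc(C(F)(F)F)c2)CC1)N1C(=O)CCC1=O`, 75%

In a functional assay on the whole organism (strain Swiss) with Mus musculus as the target, in the maximal electroshock model, with a stated time of 0.25 h, at a dose of 300 mg/kg by the intraperitoneal route (on this read-out higher numbers stand for a stronger effect at the one dose given and lower numbers for a weaker effect), compound 3 gives 75%. This number is level with that of compound 1 at the digits shown, and together the two sit at the lowest of the three numbers; compound 2 gives 100%, which lies beyond the scatter above compound 3. For the measured compounds named here, the one measured step between neighbours is a number 25 percentage points higher from compound 1 to compound 2 (beyond the scatter), a change on an aromatic carbon rather than on the chain.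

Compound 4, `CC(C(=O)N1CCN(c2cccc(C(F)(F)F)c2)CC1)N1C(=O)CCC1=O`, is the next compound. Going from compound 3 to compound 4, the change is hydrogen in place of methyl on a saturated chain carbon, two bonds along the chain from an amide-type nitrogen in a ring and a carbonyl carbon. Going by the values given here, no measured step touches this chain carbon, so the single aromatic step gives no direct guide. The two compounds carrying methyl at that chain carbon, compound 1 and compound 2, show values level with compound 3 and above it, so an outcome near compound 3 or somewhat higher seems plausible. The step is therefore expected to be a number 5 percentage points higher from compound 3 to compound 4 (within the scatter), not beyond the scatter. In this assay compound 4 is expected to give 80%, with a range from 60% to 100%.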

Compound 4, a percentage reported as activity, at one dose (the size of the read-out at that dose, not a potency): 75%
Compound 4: the middle estimate sits 5 percentage points above what was measured, and the stated range covers the measured number.
By their numbers in this assay, from the lowest: compounds 1, 3 and 4 (each within the scatter of the next); then compound 2.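

In this assay, the chain carbon now has its first measured change: hydrogen in place of methyl, which read one bond further out is ethyl to methyl, gives no change at the digits printed from compound 3 to compound 4 (within the scatter). At this one dose and with trifluoromethyl on the aromatic carbon, the read-out therefore does not separate the two chain groups, whereas the aromatic position still does. Trifluoromethyl in place of hydrogen gives a number 25 percentage points lower from compound 2 to compound 4 (beyond the scatter), while trifluoromethyl in place of methoxy gives no change at the digits printed from compound 1 to compound 4 (within the scatter), so among the compounds with the same chain, only compound 2, with hydrogen on that aromatic carbon, stands apart. Nothing at hand offers an explanation for these results.

Going by these compounds, the chain carbon has been examined only with methyl and ethyl and only alongside trifluoromethyl, so it remains open whether the same change would leave the number unmoved with hydrogen or methoxy on the aromatic carbon. Also open, on these data alone, is how this carbon would respond to a longer chain such as propyl or to an amine, and how the aromatic carbon would respond to a halogen such as chlorine.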